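This account rests on a few compounds, and the source may have more. Where it says the series, first, only, none or still open, it means among the compounds named here.

Compound 3 `O=C(C1=C(Nc2ccc(I)cc2)C(=O)N(CCCn2ccnc2)C1c1ccc(Br)cc1)c1ccccc1` gives 19400 nM in a functional assay on NCI-H1299 cells (Homo sapiens) for antiproliferative activity, read by MTT assay, with a stated time of 72 h; on this read-out lower numbers stand for stronger inhibition and higher numbers for weaker inhibition. Compound 1 `O=C(C1=C(OC2CCCCC2)C(=O)N(CCCn2ccnc2)C1c1ccc(Br)cc1)c1ccccc1` gives 19900 nM in this assay, and compound 2 `Cc1ccc(NC2=C(C(=O)c3ccccc3)C(c3ccc(Br)cc3)N(CCCn3ccnc3)C2=O)cc1` gives 25800 nM in this assay. Compound 3 holds the lowest number of the three, yet the step of a 1.0-fold lower number from compound 1 to compound 3 (0.01 log units; within the scatter) and the step of a 1.3-fold lower number from compound 2 to compound 3 (0.12 log units; within the scatter) both lie within the scatter, so the three compounds cannot be separated. Compound 4 `O=C(C1=C(NCc2ccccc2)C(=O)N(CCCn2ccnc2)C1c1ccc(Br)cc1)c1ccccc1` differs from compound 3 by benzyl in place of 4-iodophenyl on an amine nitrogen. Among the compounds with values here, no measured step makes exactly this change; the nearest is the step of a 1.0-fold lower number from compound 1 to compound 3 (0.01 log units; within the scatter), which replaces the whole group on that ring carbon and stays within the scatter. A step within the scatter is therefore expected, a 1.0-fold higher number from compound 3 to compound 4 (0.01 log units; within the scatter). Compound 4 is estimated at 20000 nM in this assay, with a range from 8000 nM to 50000 nM.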

Compound 4, half-maximal inhibitory concentration: 25300 nM
For compound 4 the middle estimate is 1.3-fold (0.10 log units) below the measured one, and the stated range covers the measured number.
By their numbers in this assay, from the lowest: compounds 3, 1, 4 and 2 (each within the scatter of the next).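

In this assay, benzyl on the amine nitrogen gives a 1.3-fold higher number from compound 3 to compound 4 (0.12 log units; within the scatter) and a 1.0-fold lower number from compound 2 to compound 4 (0.01 log units; within the scatter), while the wider change on the double-bonded ring carbon gives a 1.3-fold higher number from compound 1 to compound 4 (0.10 log units; within the scatter). The earlier compounds had shown this only for cyclohexyloxy and the two phenylamino groups; benzylamino now joins them, and all four compounds remain inseparable. Nothing available explains this result. As far as these compounds go, whether a carboxylic acid or a longer chain on this ring carbon would move the number beyond the scatter stays open, as does the effect of changes elsewhere on the shared core.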